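A few compounds are considered here, and "the series" means these few. Any claim that something is new, unique, unknown or untested is made for them only; others in the source may bear on it.

Working notes on the series. Compound 3 `COc1nc2ccc(Br)cc2cc1C(c1ccccc1)n1cc(-c2ccccc2F)nn1` gives 7.33% in an ADME assay on SK-OV-3 cells (Homo sapiens) for cytotoxicity, read by sulforhodamine B assay, with a stated time of 48 h, tested at 10 uM; a lower number here means less inhibition, a higher number more inhibition at the concentration tested (going by the name of the read-out); compound 1 `CCCCCCCc1cn(C(c2ccccc2)c2cc3cc(Br)ccc3nc2OC)nn1` gives 10.5% and compound 2 `CCCCCCc1cn(C(c2ccccc2)c2cc3cc(Br)ccc3nc2OC)nn1` gives 7.17% there, so the three numbers sit close together, with a number 3.2 percentage points lower from compound 1 to compound 3 (within the scatter) and a number 0.2 percentage points higher from compound 2 to compound 3 (within the scatter). Compound 4 `CCCCCCCCc1cn(C(c2ccccc2)c2cc3cc(Br)ccc3nc2OC)nn1` differs from compound 3 by octyl in place of 2-fluorophenyl on an aromatic carbon. Among the measured compounds shown here, the steps that bear on this change are the two in which a chain replaces the 2-fluorophenyl group: a number 3.2 percentage points lower from compound 1 to compound 3 (within the scatter) and a number 0.2 percentage points higher from compound 2 to compound 3 (within the scatter), neither beyond the scatter, and the chain-length step a number 3.3 percentage points lower from compound 1 to compound 2 (within the scatter) also stayed within it. No step beyond the scatter is therefore expected for a number 2.7 percentage points higher from compound 3 to compound 4 (within the scatter). Compound 4 is estimated at 10%, with a likely range from 3% to 18%.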

Compound 4, a percentage reported as inhibition, at one concentration (the size of the read-out at that concentration, not a potency): 2.06%
Beside the measured number, compound 4's estimate is 7.9 percentage points above it, outside the stated range (below it).
By their numbers in this assay, from the lowest: compounds 4, 2, 3 and 1 (each within the scatter of the next).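

In this assay, octyl in place of 2-fluorophenyl on this aromatic carbon gives a number 5.3 percentage points lower from compound 3 to compound 4 (within the scatter), so this open chain and the ring-bearing group remain within the scatter of each other here. The chain-length steps give a number 5.1 percentage points lower from compound 2 to compound 4 (within the scatter) and a number 8.4 percentage points lower from compound 1 to compound 4 (within the scatter), so hexyl, heptyl and octyl cannot be ordered and no trend with chain length can be claimed. No measurement at hand offers a reason for these numbers. On these data alone, whether a longer chain, an amine or a carboxylic acid at this position would give a step beyond the scatter remains open.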